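The source may hold more compounds than are shown below. What is called first, only, known or untested is meant among the compounds shown, and "the series" means these compounds.

In a functional assay on HeLa cells (Homo sapiens) for antiproliferative activity, read by MTT assay, with a stated time of 48 h (on this read-out lower numbers stand for stronger inhibition and higher numbers for weaker inhibition), compound 1 (`COC(=O)[C@H](CC(C)C)NC(=O)c1ccc(Oc2nc3ccccc3nc2C)cc1`) gives 21600 nM, compound 2 (`COC(=O)[C@H](CC(C)C)NC(=O)c1ccc(Oc2nc3ccc(Cl)cc3nc2C)cc1`) gives 37600 nM and compound 3 (`COC(=O)[C@H](CC(C)C)NC(=O)c1ccc(Oc2nc3cc(Cl)ccc3nc2C)cc1`) gives 18600 nM, so compound 1 lies within the scatter of both. Compound 4 (`Cc1nc2ccccc2nc1Oc1ccc(C(=O)N[C@@H](C)C(=O)O)cc1`) keeps the core of compound 1 but carries 1-carboxyethyl in place of 1-(methoxycarbonyl)-3-methylbutyl on an amide-type nitrogen. The two measured steps, a 1.7-fold higher number from compound 1 to compound 2 (0.24 log units; within the scatter) and a 1.2-fold lower number from compound 1 to compound 3 (0.06 log units; within the scatter), only put chloro in place of hydrogen on an aromatic carbon. Both stay within the scatter, and neither tests this change, so the forecast is tentative. The expected change in this assay is toward a higher number, an estimated 2.8-fold higher number from compound 1 to compound 4 (0.44 log units; beyond the scatter). For compound 4, the estimated value is 60000 nM, with an expected range of 15000 nM to 200000 nM.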

Compound 4, half-maximal inhibitory concentration: 22300 nM
The estimate for compound 4 lay 2.7-fold (0.43 log units) above the measured number; measured number inside the range.
By their numbers in this assay, from the lowest: compounds 3, 1, 4 and 2 (each within the scatter of the next, the first and the last beyond it).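

Putting 1-carboxyethyl in place of 1-(methoxycarbonyl)-3-methylbutyl on the amide-type nitrogen, a place the chloro steps left untouched, gives a 1.0-fold higher number from compound 1 to compound 4 (0.01 log units; within the scatter) in this assay. At this place, then, the smaller group with a hydrogen-bond donor stays within the scatter of the larger one. Nothing measured here explains this result.

This step swaps the chain and its end group together, leaving their separate contributions open; a carboxylic acid on the original 3-methylbutyl chain would separate them. Going by these compounds, an amine on this side chain also remains untested.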